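A few compounds are considered here, and "the series" means these few. Any claim that something is new, unique, unknown or untested is made for them only; others in the source may bear on it.

Among the compounds with values here, compound 3, `CCOC(=O)c1cnc(NN2C(=O)C=C(C)C2=O)nc1C`, sits in the middle of the three compounds measured so far in a functional assay on Jurkat cells (Homo sapiens) for inhibition; on this read-out higher numbers stand for weaker inhibition and lower numbers for stronger inhibition. Compound 3 gives 1900 nM. Compound 1, `CCOC(=O)c1cnc(NN2C(=O)C(C)=C(C)C2=O)nc1C(F)(F)F`, gives 3900 nM, a higher number than that of compound 3 by a gap that lies beyond the usual scatter. Compound 2, `CCOC(=O)c1cnc(N(C(=O)OCC)N2C(=O)C=C(C)C2=O)nc1C(F)(F)F`, gives 380 nM, a lower number than that of compound 3 by a gap that also lies beyond the scatter. So compound 3 inhibits more strongly than compound 1 and less strongly than compound 2.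

Compound 4, `CCOC(=O)c1cnc(NN2C(=O)C=C(C)C2=O)nc1C1CC1`, differs from compound 3 in one place only: cyclopropyl in place of methyl on an aromatic carbon. The rest of the shared core, including the ethoxycarbonyl group and the group of 9 heavy atoms, stays as it is in compound 3.

Within the data shown here, no measured pair in this set shows what this exchange does, so any expectation rests on the value of compound 3 alone. A change of the size seen here usually moves the number only modestly, and the direction cannot be read from the data. The step expected in this assay is a 1.5-fold lower number from compound 3 to compound 4 (0.16 log units; within the scatter), which is close to the scatter. Compound 4 is therefore estimated at 1300 nM, with a range from 400 nM to 4000 nM.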

Compound 4, half-maximal inhibitory concentration: 1500 nM
Compound 4: the middle estimate sits 1.2-fold (0.06 log units) below what was measured; low and high end bracket the measured number.
By their numbers in this assay, from the lowest: compound 2; then compounds 4 and 3 (each within the scatter of the next); then compound 1.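

In this assay, putting cyclopropyl in place of methyl on this aromatic carbon gives a 1.3-fold lower number from compound 3 to compound 4 (0.10 log units; within the scatter), so the two compounds cannot be told apart on this read-out. Within the data shown here, this is the first direct look at this position, since no earlier pair of compounds differed only here. It shows that, in this one pair, replacing a single carbon with a three-membered ring of 3 heavy atoms leaves the inhibition unchanged within the usual variation between repeated measurements, and nothing measured here explains why this is so.

One exchange says little about the limits of this position: an amine, a carboxylic acid, a phenyl ring or a longer chain such as butyl on the same carbon could behave quite differently from methyl and cyclopropyl, both of which are plain carbon groups with no hydrogen-bond donors or acceptors. From the compounds shown here alone, it also remains open whether the same exchange would give a similarly small step on a different version of the shared core, such as one carrying the ethyl carbamate found in compound 2.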